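Swapping the ring on the cyclopropane: pyrimidine to thiophene

This account rests on a few compounds, and the source may have more. Where it says the series, first, only, none or still open, it means among the compounds named here.

Of the compounds shown here, two from one series have been measured in a functional assay for agonist activity at G protein-coupled receptor 88 (Homo sapiens), read by HTRF and cAMP accumulation; on this read-out lower numbers stand for an effect already at smaller amounts and higher numbers for an effect only at larger amounts of compound. Compound 1 `CC[C@H](C)[C@H](N)CN(C(=O)[C@@H]1C[C@H]1c1cc(F)ccc1F)c1ccc(-c2ccccc2)cc1` gives 770 nM in this assay. Compound 2 `CC[C@H](C)[C@H](N)CN(C(=O)[C@@H]1C[C@H]1c1ncccn1)c1ccc(-c2ccccc2)cc1` gives 130 nM in this assay. Among the measured compounds shown here, compound 2 thus stands at the lowest of the two numbers, and the only other number, that of compound 1, lies a 5.9-fold lower number from compound 1 to compound 2 (0.77 log units; beyond the scatter) away from it. This single step is the whole record of what changing the aromatic ring on the saturated ring carbon does here.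

Compound 3 `CC[C@H](C)[C@H](N)CN(C(=O)[C@@H]1C[C@H]1c1cccs1)c1ccc(-c2ccccc2)cc1` has not yet been measured. It differs from compound 2 in one place: thiophen-2-yl in place of pyrimidin-2-yl on a saturated ring carbon. For the measured compounds named here, the measured step from compound 1 to compound 2 concerns the same position but a different pair of rings, so it shows only that exchanging this ring can move the number by a modest amount in this assay. It gives no direct guidance on a thiophen-2-yl ring. Compound 3 is therefore expected to give 400 nM in this assay, within a range of 130 nM to 1300 nM. This estimate means a step of a 3.1-fold higher number from compound 2 to compound 3 (0.49 log units; beyond the scatter) is expected, with low confidence on its direction.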

Compound 3, half-maximal effective concentration: 360 nM
Estimate against measurement, compound 3: 1.1-fold (0.05 log units) above; measured number inside the range.
By their numbers in this assay, from the lowest: compound 2; then compound 3; then compound 1.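

In this assay the exchange of pyrimidin-2-yl for thiophen-2-yl gives a 2.8-fold higher number from compound 2 to compound 3 (0.44 log units; beyond the scatter), so the lower number seen with the pyrimidin-2-yl ring is not simply shared by any ring other than 2,5-difluorophenyl. Thiophen-2-yl in place of 2,5-difluorophenyl still gives a 2.1-fold lower number from compound 1 to compound 3 (0.33 log units; beyond the scatter), which places the thiophen-2-yl ring between the other two, with all three compounds separated by steps beyond the scatter, and so this position on the cyclopropane tells at least three rings apart rather than two. Nothing measured here explains this order.

The exchange of pyrimidin-2-yl for thiophen-2-yl alters ring size, the kind of hetero atom and the number of hetero atoms all at once, so these three compounds cannot show which of those changes moves the number. Rings such as pyridin-2-yl, which keeps the six-membered ring with one nitrogen, or thiazol-2-yl, which keeps the five-membered ring with both sulfur and nitrogen, would pull these changes apart, and the effect of an amine or a carboxylic acid on the ring also stays open.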